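A few compounds are considered here, and "the series" means these few. Any claim that something is new, unique, unknown or untested is made for them only; others in the source may bear on it.

For the measured compounds named here, compound 1 `CCN(CC)S(=O)(=O)c1ccc(S(=O)(=O)N2CCC[C@@H](C(=O)N3CCC(F)(F)CC3)C2)cc1` gives 120 nM in a functional assay on BXPC-3 cells (Homo sapiens) for inhibition, read by MTT assay, with a stated time of 7 days (on this read-out higher numbers stand for weaker inhibition and lower numbers for stronger inhibition), the lowest of the three numbers measured so far. Compound 2 `CCN(CC)S(=O)(=O)c1ccc(S(=O)(=O)N2CCC[C@@H](C(=O)N3CCS(=O)(=O)CC3)C2)cc1` gives 4430 nM and compound 3 `CCN(CC)S(=O)(=O)c1ccc(S(=O)(=O)N2CCC[C@@H](C(=O)N3CCC(C(F)(F)F)CC3)C2)cc1` gives 370 nM; the steps of a 37-fold higher number from compound 1 to compound 2 (1.57 log units; beyond the scatter) and a 3.1-fold higher number from compound 1 to compound 3 (0.49 log units; beyond the scatter) both alter the group on the carbonyl carbon, and the step of a 12-fold lower number from compound 2 to compound 3 (1.08 log units; beyond the scatter) compares those two groups directly. Compound 4 `O=C([C@@H]1CCCN(S(=O)(=O)c2ccc(S(=O)(=O)C3COC3)cc2)C1)N1CCC(F)(F)CC1` differs from compound 1 at a different place: oxetan-3-yl in place of diethylamino on a sulfonyl sulfur. Going by the values given here, none of the measured steps touches this sulfonyl sulfur, so they offer no direct guide; they only show that a single change can move the number a great deal. Without a direct anchor, compound 4 is expected to give about 250 nM in this assay, within a wide range from 60 nM to 1200 nM, which would mean a 2.1-fold higher number from compound 1 to compound 4 (0.32 log units; beyond the scatter).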

Compound 4, half-maximal inhibitory concentration: 361 nM
Beside the measured number, compound 4's estimate is 1.4-fold (0.16 log units) below it; the measured number falls inside the stated range.
By their numbers in this assay, from the lowest: compound 1; then compounds 4 and 3 (each within the scatter of the next); then compound 2.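

Swapping the group on this sulfonyl sulfur also moves the number, though only modestly: with oxetan-3-yl in place of diethylamino there is a 3.0-fold higher number from compound 1 to compound 4 (0.48 log units; beyond the scatter). An open group without a ring gives way to a four-membered ring holding an oxygen, and inhibition weakens but is not lost. Nothing available explains the size of this step.

On these data alone, it remains open whether the ring, the oxygen or the smaller heavy-atom count accounts for the step. A cyclobutyl group on the same sulfonyl sulfur would keep the four-membered ring without the oxygen, which would help separate these.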